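From a Pentyl Chain to a Bromophenyl Ring

The compounds below may be only part of what the source reports. "The series", "measured", "known", "first", "only" and "open" are said of these compounds alone.

Compound 1 `COc1cc(-c2nccn2C)cc(OC)c1OC` is the starting point. In a functional assay on T47D cells (Homo sapiens) for antiproliferative activity, read by MTT assay, with a stated time of 72 h (a higher number here means a weaker inhibitor, a lower number a stronger inhibitor), compound 1 reaches only the limit of the assay, > 100000 nM, so no number is known for it. Compound 2 `CCCCCn1ccnc1-c1cc(OC)c(OC)c(OC)c1` differs by butyl in place of hydrogen on a saturated chain carbon bound to an aromatic nitrogen, and in this assay compound 2 gives 64400 nM. Among the measured compounds shown here, the step of an at least 1.5-fold lower number from compound 1 to compound 2 (0.19 log units; that floor lies within the scatter) is therefore the only comparison available, and it rests on a limit (the limit of > 100000 nM in this assay, at which 1 of the 2 values shown sits), so its true size is uncertain. For the measured compounds named here, compound 2 stands as the sole compound with a number in this assay.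

Compound 3 `COc1cc(-c2nccn2-c2ccc(Br)cc2)cc(OC)c1OC` is not yet measured. It differs from compound 2 by 4-bromophenyl in place of pentyl on an aromatic nitrogen. Going by the values given here, no measured step exchanges a chain for an aromatic ring at this position; the single step known exchanges hydrogen for a chain, and it lies within the scatter. In this assay compound 3 is therefore expected to show a 1.6-fold lower number from compound 2 to compound 3 (0.21 log units; within the scatter), a step not clearly beyond the scatter. The estimate for compound 3 is 40000 nM, with a range from 8000 nM to 100000 nM.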

Compound 3, half-maximal inhibitory concentration: 24600 nM
Beside the measured number, compound 3's estimate is 1.6-fold (0.21 log units) above it, and the stated range covers the measured number.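

The aromatic nitrogen of the shared core does respond to what it carries. In this assay, among the compounds shown here, the step of a 2.6-fold lower number from compound 2 to compound 3 (0.42 log units; beyond the scatter) is the first here with a real number at both ends, and it stands clear of the usual scatter, so exchanging a flexible chain for an aromatic ring at this position makes a measurable difference. Compound 1 sits at a limit of the assay, so the step of an at least 4.0-fold lower number from compound 1 to compound 3 (0.60 log units; beyond the scatter) gives only a floor for the change from methyl to 4-bromophenyl, though even that floor lies beyond the scatter: the limit of > 100000 nM in this assay, at which 1 of the 3 values shown sits.

Compound 3 has the lowest number of the three, yet at 24600 nM it remains a weak inhibitor in absolute terms.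

The compounds shown leave open whether the aromatic ring or the bromine accounts for the step, as both enter together; a plain phenyl ring on the same nitrogen would separate the two. From the compounds shown here alone, it is also open how a ring carrying an amine or a carboxylic acid in place of the bromine would behave in this assay.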